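This account rests on a few compounds, and the source may have more. Where it says the series, first, only, none or still open, it means among the compounds named here.

Measured so far in an assay on CHO cells for displacement of a labelled ligand from histamine receptor H3 (Macaca mulatta); a lower number here means a stronger inhibitor, a higher number a weaker inhibitor:
Compound 1 `CC1CCCN1C1CCN(c2ccc(NC(=O)CC3CCCC3)cc2)C1` gives 3.1 nM.
Compound 2 `CC1CCCN1C1CCN(c2ccc(NC(=O)C3C(C)(C)C3(C)C)cc2)C1` gives 144 nM.
Compound 3 `CC(=O)N1CCCC1C(=O)Nc1ccc(N2CCC(N3CCCC3C)C2)cc1` gives 14.1 nM.

Compound 3 holds the second highest of the three numbers: a 4.5-fold higher number from compound 1 to compound 3 (0.66 log units; beyond the scatter) and a 10-fold lower number from compound 2 to compound 3 (1.01 log units; beyond the scatter). Compound 4 `CC1CCCN1C1CCN(c2ccc(NC(=O)C3CCCO3)cc2)C1` differs from compound 3 only at the carbonyl carbon, where (oxolan-2-yl in place of 1-acetylpyrrolidin-2-yl on a carbonyl carbon). Both earlier steps touch exactly this position and show that what sits there matters: a 46-fold higher number from compound 1 to compound 2 (1.67 log units; beyond the scatter) was large, while the step to compound 3 was modest. Going by the values given here, the entering oxolan-2-yl ring is smaller than any group seen so far, so no close precedent exists, and a shift in this assay within or just beyond the scatter is expected. Compound 4 is estimated at 20 nM, with a range from 6 nM to 70 nM, meaning an expected step of a 1.4-fold higher number from compound 3 to compound 4 (0.15 log units; within the scatter).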

Compound 4, inhibition constant: 8.7 nM
Compound 4: the middle estimate sits 2.3-fold (0.36 log units) above what was measured; the measured number falls inside the stated range.
By their numbers in this assay, from the lowest: compound 1; then compounds 4 and 3 (each within the scatter of the next); then compound 2.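

On the carbonyl carbon, a 1.6-fold lower number from compound 3 to compound 4 (0.21 log units; within the scatter) in this assay shows that oxolan-2-yl, with 5 heavy atoms, can replace 1-acetylpyrrolidin-2-yl, with 8, without a change beyond the scatter. Oxolan-2-yl still stands apart from the two groups without a hetero atom, with a 17-fold lower number from compound 2 to compound 4 (1.22 log units; beyond the scatter) against 2,2,3,3-tetramethylcyclopropyl and a 2.8-fold higher number from compound 1 to compound 4 (0.45 log units; beyond the scatter) against cyclopentylmethyl. No measurement is available to explain these differences. From the compounds shown here alone, what remains open is how an amine such as piperidin-2-yl or an open chain such as 2-methoxyethyl would compare at this carbonyl carbon. Cyclopentyl, which lacks the single carbon linking the ring of cyclopentylmethyl to the carbonyl, is also an open case.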